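Swapping Methyl for Bromine on the Aryl Ring

The compounds below may be only part of what the source reports. "The series", "measured", "known", "first", "only" and "open" are said of these compounds alone.

Compound 1 `C=C1C(=O)ON(C)C1C(C)CCC` and compound 2 `C=C1C(=O)ON(C)C1c1ccc(C)cc1` share one core and differ in the group attached to it. In a functional assay on HL-60 cells (Homo sapiens) for antiproliferative activity (on this read-out higher numbers stand for weaker inhibition and lower numbers for stronger inhibition), compound 2 gives 5400 nM. In this assay compound 1 gives 4700 nM, and the two numbers lie within the scatter of each other, so neither can be called the stronger inhibitor. Compound 3 `C=C1C(=O)ON(C)C1c1ccc(Br)cc1` differs from compound 2 by bromo in place of methyl on an aromatic carbon. Going by the values given here, no measured pair shows what this change does here, so no shift beyond the scatter is expected. Compound 3 is estimated to give about 4500 nM, with a range from 1500 nM to 13000 nM. The expected step of a 1.2-fold lower number from compound 2 to compound 3 (0.08 log units; within the scatter) stays inside the usual scatter.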

Compound 3, half-maximal inhibitory concentration: 5100 nM
Estimate against measurement, compound 3: 1.1-fold (0.05 log units) below; low and high end bracket the measured number.
By their numbers in this assay, from the lowest: compounds 1, 3 and 2 (each within the scatter of the next).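

In this assay, going by these compounds alone, putting bromo in place of methyl on this aromatic carbon gives a 1.1-fold lower number from compound 2 to compound 3 (0.02 log units; within the scatter) and so offers the first direct comparison at this position. The two groups cannot be told apart on this read-out, so this change leaves antiproliferative activity effectively unchanged here. Nothing available explains this result.

Still open, from the compounds shown here alone, is whether an amine or a carboxylic acid on this same aromatic carbon would move the number beyond the scatter. Going by these compounds, whether bromo and methyl would also match on another carbon of the ring remains open too.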